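The source may hold more compounds than are shown below. What is called first, only, known or untested is meant among the compounds shown, and "the series" means these compounds.

Measured so far:
compound 1 `O=C(COc1cccc2ccccc12)N/N=C/c1cccc(O)c1` — 100 ug/mL
compound 2 `C/C(=N\NC(=O)COc1cccc2ccccc12)c1ccc(O)cc1` — 20 ug/mL
compound 3 `O=C(COc1cccc2ccccc12)N/N=C/c1ccccc1Cl` — 100 ug/mL

In an ADME assay on HEL cells (Homo sapiens) for cytotoxicity (a higher number here means that more compound is tolerated, a lower number that less compound is tolerated), compound 2 gives the lowest of the three numbers; compound 1 and compound 3 both sit at a number well beyond the scatter above it. Compound 4 `C/C(=N\NC(=O)COc1cccc2ccccc12)c1ccccc1` is not yet measured. It differs from compound 2 as follows: hydrogen in place of hydroxy on an aromatic carbon.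

Among the compounds with values here, only one measured step bears on this change, and only loosely: no change at the digits printed from compound 1 to compound 3 (within the scatter). That step swapped the hydroxy-bearing ring for a chloro-bearing one without moving the number. Within the data shown here, no step connects compound 2 to compound 1 or compound 3, since compound 2 also carries a methyl on the carbon with a double bond to nitrogen and its hydroxy sits at a different place on the ring.

Taken together, the shown step gives no ground to expect a move beyond the scatter; the estimated step is a 1.5-fold higher number from compound 2 to compound 4 (0.18 log units; within the scatter), leaning slightly toward more tolerated compound because compound 1 and compound 3 both sit at 100 ug/mL. Compound 4 is therefore expected at 30 ug/mL, in the range 10 ug/mL to 100 ug/mL.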

Compound 4, minimum cytotoxic concentration: 20 ug/mL
Beside the measured number, compound 4's estimate is 1.5-fold (0.18 log units) above it; measured number inside the range.
By their numbers in this assay, from the lowest: compounds 2 and 4 (each within the scatter of the next); then compounds 1 and 3 (each within the scatter of the next).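

In this assay, the change from 4-hydroxyphenyl to phenyl gives no change at the digits printed from compound 2 to compound 4 (within the scatter). Within the data shown here, this is the first step read on an aromatic carbon para to a large group, and the first among compounds carrying a methyl on the carbon with a double bond to nitrogen; the hydroxy at this place is not required for the number seen with compound 2. No measurement shown accounts for this result.

No pair shown differs only in that methyl, so its contribution cannot be read from these compounds. Among these compounds, whether the flat result holds at this place for other groups, such as an amine or a carboxylic acid, also stays open, as the hydroxy and hydrogen pair is the only comparison available there.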